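The source may report more compounds than this note shows. Statements on the series, on what has been measured and on what is new or still open speak of the compounds shown alone.

Of the compounds shown here, two have been measured in an assay on cells for agonist activity at ecdysone receptor (Bombyx mori), read by a luciferase reporter, with a stated time of 24 h (on this read-out lower numbers stand for an effect already at smaller amounts and higher numbers for an effect only at larger amounts of compound), so far. Compound 1 `Cc1ccc(C(=O)NN(C(=O)c2ccccc2Cl)C(C)(C)C)cc1` gives 18.6 nM in this assay. Compound 2 `CCOc1ccccc1C(=O)N(NC(=O)c1ccc(CC)cc1)C(C)(C)C` gives 2880 nM in this assay, the higher of the two numbers, and its gap to compound 1 lies well beyond the usual scatter of such measurements. Compound 3 `CCc1ccc(C(=O)NN(C(=O)C2CCCCC2)C(C)(C)C)cc1` has not been measured yet. It differs from compound 2 in one place: cyclohexyl in place of 2-ethoxyphenyl on a carbonyl carbon. Going by the values given here, no measured pair shows this particular exchange, so its effect can only be judged from the wide span between the two known values. Compound 2 stands at the weak end of that span, and a moderate move toward lower numbers is expected, the step of a 4.8-fold lower number from compound 2 to compound 3 (0.68 log units; beyond the scatter) being an estimate rather than a measured fact. In this assay compound 3 is therefore expected to give about 600 nM, within a range from 120 nM to 3000 nM.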

Compound 3, half-maximal effective concentration: 9330 nM
Estimate against measurement, compound 3: 16-fold (1.19 log units) below, and the stated range ends below it.
By their numbers in this assay, from the lowest: compound 1; then compound 2; then compound 3.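

Read in this assay, cyclohexyl in place of 2-ethoxyphenyl on a carbonyl carbon brings a 3.2-fold higher number from compound 2 to compound 3 (0.51 log units; beyond the scatter) and so shows that this position responds to the exchange. A higher number here means that more compound is needed for the effect, so this non-aromatic ring of carbon only does not restore activity at this place. No measurement at hand offers an explanation for the step.

Going by these compounds, the aromatic ring and the ethoxy group's oxygen leave together in this exchange, so their separate contributions remain unknown. On these data alone, whether a plain phenyl, a 2-methoxyphenyl or a pyridine ring on this carbonyl carbon would give a lower or a higher number also remains open.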